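A few compounds are considered here, and "the series" means these few. Any claim that something is new, unique, unknown or untested is made for them only; others in the source may bear on it.

Measured in an ADME assay on liver (Rattus norvegicus) for metabolic stability, read by LC-MS, using microsomes and NADPH, with a stated time of 40 min, tested at 1 uM; on this read-out lower numbers stand for slow clearance and higher numbers for fast clearance:

Compound 1 `COc1cc(C(F)(F)F)ccc1-c1cccc2cc(S(=O)(=O)Nc3ccncn3)ccc12`: < 14 mL.min-1.g-1
Compound 2 `COc1cc(C(F)(F)F)ccc1-c1cccc2cc(S(=O)(=O)Nc3ncccn3)ccc12`: < 14 mL.min-1.g-1

Neither entry is a number. Compound 2 stands at < 14 mL.min-1.g-1, which is a limit of the assay. Compound 1, at < 14 mL.min-1.g-1, also gives only a limit. The picture in this assay is therefore (the limit of < 14 mL.min-1.g-1 in this assay, at which 2 of the 2 values shown sit).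

Compound 3 `COc1cc(C(F)(F)F)ccc1-c1cccc2cc(S(=O)(=O)Nc3cncs3)ccc12` keeps the shared core of compound 2 and changes only the group on the sulfonamide nitrogen, with 1,3-thiazol-5-yl in place of pyrimidin-2-yl on a sulfonamide nitrogen.

Among the compounds with values here, one measured step bears on this, the swap at the same place on the sulfonamide nitrogen: a step that the two limits leave unreadable from compound 1 to compound 2. It offers no size to carry over, and it concerns two six-membered rings, whereas compound 3 brings a five-membered ring with sulfur. No firm direction can be drawn from it, so the expected change is small, and a number no lower from compound 2 to compound 3 (the limit leaves the size open) is the estimated step, with nothing expected beyond the scatter. For compound 3 the estimated value is 14 mL.min-1.g-1, with an expected range from 9 mL.min-1.g-1 to 35 mL.min-1.g-1.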

Compound 3, intrinsic clearance in microsomes: 37 mL.min-1.g-1
Compound 3: the middle estimate sits 2.6-fold (0.42 log units) below what was measured; measured number outside the range, above it.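

Exchanging the six-membered rings on the sulfonamide nitrogen for 1,3-thiazol-5-yl produces a readable change in this assay: replacing pyrimidin-2-yl gives an at least 2.6-fold higher number from compound 2 to compound 3 (0.42 log units; beyond the scatter), and replacing pyrimidin-4-yl gives an at least 2.6-fold higher number from compound 1 to compound 3 (0.42 log units; beyond the scatter). Within the data shown here, compound 3 is the first compound here to give a number rather than a limit, which shows that the group at this place can move the read-out towards faster clearance, something the unreadable step between the two pyrimidine compounds could not show. The full size of both new steps remains unknown, as each starts from a limit and not from a number: the limit of < 14 mL.min-1.g-1 in this assay, at which 2 of the 3 values shown sit.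

The 1,3-thiazol-5-yl group differs from both pyrimidinyl groups in ring size and in carrying sulfur, so the compounds shown do not separate these two differences. On these data alone, it also remains open how this read-out would respond at the same place to a 1,3-oxazol-5-yl group, which has oxygen where the thiazole has sulfur, or to a 1,3-thiazol-2-yl group, which joins the same ring to the nitrogen through a different atom.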